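A few compounds are considered here, and "the series" means these few. Any claim that something is new, unique, unknown or untested is made for them only; others in the source may bear on it.

Measured compounds:
- compound 1, `CC1(c2ccccc2)CC(=O)N(CC(=O)N2CCN(c3ccc(Cl)cc3)CC2)C1=O`: "not active" (no number reported)
- compound 2, `Cc1cccc(N2CCN(C(=O)CN3C(=O)CC(C)(c4ccccc4)C3=O)CC2)c1`: 100 mg/kg
- compound 3, `CC1(c2ccccc2)CC(=O)N(CC(=O)N2CCN(c3ccc(Cl)c(Cl)c3)CC2)C1=O`: "not active" (no number reported)

These three compounds share one core and differ only in the aryl group attached to the piperazine. They were tested in a functional assay on the whole organism (strain CD-1) with Mus musculus as the target, in the maximal electroshock model, with a stated time of 0.5 h; on this read-out lower numbers stand for an effect already at smaller amounts and higher numbers for an effect only at larger amounts of compound. Compound 2 gives 100 mg/kg, the only numerical result in the set. Compound 1 is recorded as "not active" (no number reported). Compound 3 likewise is recorded as "not active" (no number reported), so it stands without a number, at the weak end of what the set shows, together with compound 1; no comparison in size between these two compounds is possible.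

The next compound, compound 4, `CC1(c2ccccc2)CC(=O)N(CC(=O)N2CCN(c3cccc(C(F)(F)F)c3)CC2)C1=O`, has not yet been tested. It differs from compound 3 by one change: 3-(trifluoromethyl)phenyl in place of 3,4-dichlorophenyl on an amine nitrogen in a ring. Within the data shown here, since compound 3 has no number in this assay, no step of a definite size can be computed, and the expectation for compound 4 is only that it will be no worse than compound 3, with a real chance that it too returns no number. Given that compound 2 reaches 100 mg/kg while compound 1 and compound 3 do not, compound 4 is estimated at 150 mg/kg, with a range from 60 mg/kg to 400 mg/kg.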

Compound 4, minimum effective dose: 300 mg/kg
Compound 4: the middle estimate sits 2.0-fold (0.30 log units) below what was measured; the range from low to high includes it.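

In this assay, compound 4 shows that the aryl group on the amine nitrogen in the ring can be a 3-(trifluoromethyl)phenyl and still give a numerical result, whereas compound 3, with 3,4-dichlorophenyl at the same place, stays without one, so any step between these two cannot be read, nor can any other step involving a compound without a number. Among these compounds, the first readable comparison at this position is trifluoromethyl in place of methyl on an aromatic carbon, which gives a 3.0-fold higher number from compound 2 to compound 4 (0.48 log units; beyond the scatter), a modest change beyond the usual scatter, with a larger dose needed for the same effect. Nothing measured here explains this difference or the contrast with compound 3.

With only two numerical results, no trend across aryl groups can be drawn, and the compounds shown leave open how a methoxy group, a nitrile or a plain phenyl would behave at this place. They also leave open whether an ethyl group in place of the methyl on the shared core would change the picture for the aryl groups seen so far.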